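Iodo on the aromatic ring of compound 3

The source may hold more compounds than are shown below. What is called first, only, known or untested is meant among the compounds shown, and "the series" means these compounds.

In a functional assay on KB cells (Homo sapiens) for antiproliferative activity, read by sulforhodamine B assay, with a stated time of 3 days (a higher number here means that more compound is needed for the effect, a lower number that less compound is needed), compound 3 `CCCOC1=C(CCC)C(=O)/C(=C(O)/C=C/c2ccccc2)C(=O)C1(CCC)CCC` gives 2.7 uM, within the scatter of both compound 1 `CCCC1=C(OC)C(CCC)(CCC)C(=O)/C(=C(O)\C=C\c2ccccc2)C1=O` at 4.6 uM and compound 2 `CCCC1=C(OC)C(CCC)(CCC)C(=O)/C(=C(O)\C=C\c2ccc(I)cc2)C1=O` at 1.5 uM. Compound 4 `CCCOC1=C(CCC)C(=O)/C(=C(O)/C=C/c2ccc(I)cc2)C(=O)C1(CCC)CCC` differs from compound 3 by iodo in place of hydrogen on an aromatic carbon, para to a large group. The same exchange has one precedent, a 3.1-fold lower number from compound 1 to compound 2 (0.49 log units; beyond the scatter), a modest step beyond the scatter. The other measured step, a 1.7-fold lower number from compound 1 to compound 3 (0.23 log units; within the scatter), lies within the scatter and concerns a different place, so it offers little guidance. A modest step to a lower number is therefore expected, a 2.7-fold lower number from compound 3 to compound 4 (0.43 log units; beyond the scatter), resting on that single pair. For compound 4 the estimate is 1 uM, with an expected range of 0.4 uM to 2.2 uM.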

Compound 4, concentration for half-maximal effect: 6.4 uM
Compound 4: middle estimate off by 6.4-fold (0.81 log units), on the low side; the measured number lies above the stated range.
By their numbers in this assay, from the lowest: compounds 2, 3, 1 and 4 (each within the scatter of the next, the first and the last beyond it).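

With iodo in place of hydrogen, this assay now shows a 2.4-fold higher number from compound 3 to compound 4 (0.37 log units; beyond the scatter), so the change from phenyl to 4-iodophenyl has no single direction across the two cores: the same change on two cores in this assay, a 3.1-fold lower number (0.49 log units; beyond the scatter) from compound 1 to compound 2 and a 2.4-fold higher number (0.37 log units; beyond the scatter) from compound 3 to compound 4, 7.3-fold (0.86 log units) apart, beyond the scatter of two such steps

The ethyl exchange, within the scatter without iodo, becomes a 4.3-fold higher number from compound 2 to compound 4 (0.63 log units; beyond the scatter) once the 4-iodophenyl group is present, so the two places do not act independently here: the same change on two cores in this assay, a 1.7-fold lower number (0.23 log units; within the scatter) from compound 1 to compound 3 and a 4.3-fold higher number (0.63 log units; beyond the scatter) from compound 2 to compound 4, 7.3-fold (0.86 log units) apart, beyond the scatter of two such steps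

On these data alone, whether a chloro, a methoxy or an amine on the same aromatic carbon would separate the two cores in the same way stays open.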